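Adding a methoxy to compound 3

The source may hold more compounds than are shown below. What is called first, only, known or untested is meant among the compounds shown, and "the series" means these compounds.

Three amides sharing one core have been tested in a functional assay on HOS-TE85 cells (Homo sapiens) for inhibition, read by CCK-8 assay, with a stated time of 72 h (a lower number here means a stronger inhibitor, a higher number a weaker inhibitor), so far. Compound 1 (`COc1ccc(OC)c(N2C(=O)CSC2c2cccc(C(=O)NCCCCc3ccccc3)c2)c1`) returned only a limit of the assay (> 1000 nM). Compound 3 (`O=C(NCCCCc1ccccc1)c1cccc(C2SCC(=O)N2c2cccc(F)c2)c1`) gives 32.4 nM as the higher of the two actual numbers, while compound 2 (`COc1ccc(F)cc1N1C(=O)CSC1c1cccc(C(=O)NCCCCc2ccccc2)c1`) gives 8.8 nM as the lower.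

Compound 4 (`COc1c(F)cccc1N1C(=O)CSC1c1cccc(C(=O)NCCCCc2ccccc2)c1`) differs from compound 3 in one place (methoxy in place of hydrogen on an aromatic carbon): methoxy in place of hydrogen on an aromatic carbon, ortho to a fluoro group and ortho to a large group.

Two large steps (an at least 110-fold lower number from compound 1 to compound 2 (2.05 log units; beyond the scatter)) and (an at least 30-fold lower number from compound 1 to compound 3 (1.48 log units; beyond the scatter)) show that changes to this aromatic group can matter greatly, although both start from a limit and so have no exact size. The closest guide is the modest step for hydrogen in place of methoxy (a 3.7-fold higher number from compound 2 to compound 3 (0.57 log units; beyond the scatter)). Read in reverse, it suggests that adding a methoxy could lower the number modestly. However, compound 2 carries its methoxy on a different carbon, and compound 1 shows that a methoxy-bearing group can also do far worse.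

A small step that leans lower and probably stays within the scatter is therefore expected (a 1.3-fold lower number from compound 3 to compound 4 (0.11 log units; within the scatter)). Compound 4 is estimated at (25 nM) with an expected range (6 nM to 130 nM).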

Compound 4, half-maximal inhibitory concentration: 26.2 nM
Estimate against measurement, compound 4: 1.0-fold (0.02 log units) below; measured number inside the range.
By their numbers in this assay, from the lowest: compound 2; then compounds 4 and 3 (each within the scatter of the next). At a limit, above all of these: compound 1.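

In this assay, a methoxy on the aromatic carbon ortho to a fluoro group and ortho to a large group has no effect that can be told from the scatter, with a 1.2-fold lower number from compound 3 to compound 4 (0.09 log units; within the scatter); so the modest gain seen with the methoxy of compound 2 does not carry over to this carbon. With a fluoro group and a methoxy both present, their arrangement on the ring still counts, as the change to 3-fluoro-2-methoxyphenyl from 5-fluoro-2-methoxyphenyl gives a 3.0-fold higher number from compound 2 to compound 4 (0.47 log units; beyond the scatter). A methoxy on this ring also does not by itself bring the poor result of compound 1, as the data show an at least 38-fold lower number from compound 1 to compound 4 (1.58 log units; beyond the scatter), a step whose starting point is a limit of the assay and not a number: the limit of > 1000 nM in this assay, at which 1 of the 4 values shown sits.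

The compounds shown leave open whether a larger ethoxy, a hydroxy or an amine on the same carbon would match the methoxy. They also leave open whether the methoxy would remain without effect if the fluoro group gave way to a chlorine or a methyl.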